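Methyl loss and a dimethoxyphenyl swap in a benzimidazole series

This account rests on a few compounds, and the source may have more. Where it says the series, first, only, none or still open, it means among the compounds named here.

Compound 1 `Cc1ccc2[nH]c(-c3ccc(-c4ccc(-c5cccc(Cl)c5)cc4)cc3)nc2c1`: 3450 nM
Compound 2 `COc1ccc(-c2ccc(-c3ccc(-c4nc5cc(C)ccc5[nH]4)cc3)cc2)cc1OC`: 3100 nM
Compound 3 `Clc1cccc(-c2ccc(-c3ccc(-c4nc5ccccc5[nH]4)cc3)cc2)c1`: 41200 nM

Of the compounds shown here, three of one family have been measured in a functional assay on ZR-75-1 cells (Homo sapiens) for inhibition, read by sulforhodamine B assay; on this read-out higher numbers stand for weaker inhibition of growth and lower numbers for stronger inhibition of growth. Compound 1 `Cc1ccc2[nH]c(-c3ccc(-c4ccc(-c5cccc(Cl)c5)cc4)cc3)nc2c1` gives 3450 nM in this assay. Compound 2 `COc1ccc(-c2ccc(-c3ccc(-c4nc5cc(C)ccc5[nH]4)cc3)cc2)cc1OC` gives 3100 nM, and the change that leads there, (3,4-dimethoxyphenyl in place of 3-chlorophenyl on an aromatic carbon), made a step of a 1.1-fold lower number from compound 1 to compound 2 (0.05 log units; within the scatter). Compound 3 `Clc1cccc(-c2ccc(-c3ccc(-c4nc5ccccc5[nH]4)cc3)cc2)c1` gives 41200 nM, the highest number of the three; here the core differs from that of compound 1 by hydrogen in place of methyl on an aromatic carbon, and this made a step of a 12-fold higher number from compound 1 to compound 3 (1.08 log units; beyond the scatter).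

Compound 4 `COc1ccc(-c2ccc(-c3ccc(-c4nc5ccccc5[nH]4)cc3)cc2)cc1OC` has not yet been measured in this assay. It differs from compound 3 by 3,4-dimethoxyphenyl in place of 3-chlorophenyl on an aromatic carbon, the same change that separates compound 2 from compound 1, made on the core of compound 3 rather than the core of compound 1. Since that change gave only a 1.1-fold lower number from compound 1 to compound 2 (0.05 log units; within the scatter) on the first core, the expected step from compound 3 to compound 4 in this assay is about a 1.1-fold lower number from compound 3 to compound 4 (0.05 log units; within the scatter), resting on that single earlier step. In this assay compound 3 gives 41200 nM, and the estimate starts from that number. For the measured compounds named here, compound 4 is therefore estimated at 37000 nM, with a range from 15000 nM to 90000 nM, the width reflecting that only one prior instance of the change is known.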

Compound 4, concentration for 50% growth inhibition: 39700 nM
For compound 4 the middle estimate is 1.1-fold (0.03 log units) below the measured one; the range from low to high includes it.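

In this assay, placing 3,4-dimethoxyphenyl where 3-chlorophenyl stood on the core of compound 3 gave a 1.0-fold lower number from compound 3 to compound 4 (0.02 log units; within the scatter), which matches what the same change did on the other core: the same change on two cores in this assay, a 1.1-fold lower number (0.05 log units; within the scatter) from compound 1 to compound 2 and a 1.0-fold lower number (0.02 log units; within the scatter) from compound 3 to compound 4, 1.1-fold (0.03 log units) apart, within the scatter of two such steps. The other change also carried over, as hydrogen in place of methyl on an aromatic carbon gave a 13-fold higher number from compound 2 to compound 4 (1.11 log units; beyond the scatter), in line with its earlier step: the same change on two cores in this assay, a 12-fold higher number (1.08 log units; beyond the scatter) from compound 1 to compound 3 and a 13-fold higher number (1.11 log units; beyond the scatter) from compound 2 to compound 4, 1.1-fold (0.03 log units) apart, within the scatter of two such steps. Across these four compounds, then, each change gave the same result whichever form of the other place it met, with the swap of 3-chlorophenyl for 3,4-dimethoxyphenyl making no step beyond the scatter and the loss of methyl making a large one, but this rests on only two cores that differ by a single methyl and does not show that either step would hold on any other core or explain why the methyl counts for so much.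

The compounds shown leave open whether an ethyl group or a chlorine in place of the methyl would keep the lower numbers seen with compound 1 and compound 2. They also leave open whether a phenyl carrying an amine or a carboxylic acid, in place of 3-chlorophenyl, would give numbers like those of the two groups compared here.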